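A few compounds are considered here, and "the series" means these few. Any claim that something is new, unique, unknown or untested is made for them only; others in the source may bear on it.

Compound 1 `CCOC(=O)C1=Cc2ccccc2OC1(OCc1cn(-c2ccc(F)cc2)nn1)C(F)(F)F` sits at the lower end of the numbers gathered here. In a functional assay on A549 cells (Homo sapiens) for inhibition, read by MTT assay, with a stated time of 24 h (a higher number here means a weaker inhibitor, a lower number a stronger inhibitor), compound 1 gives 7300 nM, and compound 3 `COc1ccc(-c2cc(COC3(C(F)(F)F)Oc4ccccc4C=C3C(=O)O)on2)cc1` gives 36200 nM, a gap beyond the usual scatter. Compound 2 `CCOC(=O)C1=Cc2ccccc2OC1(OCc1cc(-c2ccc3ccccc3c2)no1)C(F)(F)F` reached only a limit of the assay (the limit of > 150000 nM in this assay, at which 1 of the 3 values shown sits); in this assay compound 2 gives > 150000 nM. The next compound, compound 4 `CCOC(=O)C1=Cc2ccccc2OC1(OCc1cn(CC(=O)NC2CCCCC2)nn1)C(F)(F)F`, differs from compound 1 in one place: (cyclohexylcarbamoyl)methyl in place of 4-fluorophenyl on an aromatic nitrogen. For the measured compounds named here, no measured pair here shows such an exchange, so its size is uncertain. The step from compound 1 to compound 4 is expected to be a modest weakening, a 2.1-fold higher number from compound 1 to compound 4 (0.31 log units; beyond the scatter), somewhat beyond the scatter. In this assay compound 4 is therefore estimated at 15000 nM, with a likely range from 4000 nM to 60000 nM.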

Compound 4, half-maximal inhibitory concentration: 9900 nM
For compound 4 the middle estimate is 1.5-fold (0.18 log units) above the measured one; the measured number falls inside the stated range.
By their numbers in this assay, from the lowest: compounds 1 and 4 (each within the scatter of the next); then compound 3. At a limit, above all of these: compound 2.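

In this assay, placing (cyclohexylcarbamoyl)methyl in place of 4-fluorophenyl on an aromatic nitrogen gives a 1.4-fold higher number from compound 1 to compound 4 (0.13 log units; within the scatter), so the two compounds cannot be told apart. This position therefore accepts either a six-membered aromatic ring of carbon only or a larger group with a non-aromatic ring, a hydrogen-bond donor and a hydrogen-bond acceptor. No measurement shown here bears on why the two numbers match. From the compounds shown here alone, it remains open whether a longer chain ending in an amine would fit this nitrogen equally well.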